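Series notes: 2-cyanobenzyl to 2-methylbenzyl on the shared core

The source may hold more compounds than are shown below. What is called first, only, known or untested is meant among the compounds shown, and "the series" means these compounds.

Measured compounds:
Compound 1 `CSCC[C@H](NC(=O)c1ccc(NCc2cncn2Cc2ccccc2C#N)cc1-c1ccccc1)C(=O)O`; in a functional assay on NIH3T3 cells (Mus musculus) (on this read-out lower numbers stand for an effect already at smaller amounts and higher numbers for an effect only at larger amounts of compound), compound 1 reaches only the assay limit, > 10 uM.
Compound 2 `COC(=O)[C@H](CCSC)NC(=O)c1ccc(NCc2cncn2Cc2ccccc2C#N)cc1-c1ccccc1`; in this assay compound 2 likewise returns a limit, > 10 uM.

Among the measured compounds shown here, compound 1 therefore stands at the limit of this assay, and the one further value shown is a limit as well. For the measured compounds named here, the single measured step, a step that the two limits leave unreadable from compound 1 to compound 2, is methyl in place of hydrogen on an oxygen next to a carbonyl group; its size cannot be read because of the limit of > 10 uM in this assay, at which 2 of the 2 values shown sit, so it gives no scale for the series.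

Compound 3 `CSCC[C@H](NC(=O)c1ccc(NCc2cncn2Cc2ccccc2C)cc1-c1ccccc1)C(=O)O` differs from compound 1 by methyl in place of cyano on an aromatic carbon, that is 2-cyanobenzyl to 2-methylbenzyl. Going by the values given here, no measured step touches this part of the molecule, and the only step available is unreadable, so the numbers give no guide to the size or direction of this change. The step that is expected here, a step that the limit leaves unreadable from compound 1 to compound 3, is therefore only an estimate that compound 3 remains near the limit. Compound 1 itself sits at the limit, > 10 uM. Compound 3 is estimated at 15 uM, with a range from 4 uM to 60 uM.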

Compound 3, concentration for half-maximal effect: > 10 uM
Compound 3 gave a limit, no number; the forecaster's own chance of this, stated with the estimate: 70%; the middle value does not contradict the limit.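

No new step can be read: the change from compound 1 to compound 3, 2-cyanobenzyl to 2-methylbenzyl, joins two values that are both limits, and the only reading available is this: the limit of > 10 uM in this assay, at which 3 of the 3 values shown sit.

The compounds shown leave open the size and direction of either change in this assay, and what on the shared core would bring a value inside the measurable range.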